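Sulfur-linked bicyclic heteroaryl ureas, sterol O-acyltransferase 1 inhibition

A few compounds are considered here, and "the series" means these few. Any claim that something is new, unique, unknown or untested is made for them only; others in the source may bear on it.

Compound 1, `CCCCCCN(CCCCCSc1nc2ccccc2s1)C(=O)Nc1ccc(F)cc1F`: 4000 nM in an assay on microsomes from liver for inhibition of sterol O-acyltransferase 1 (Rattus norvegicus); a higher number here means a weaker inhibitor, a lower number a stronger inhibitor
Compound 2, `CCCCCCCN(CCCCCSc1nc(N)c2c[nH]nc2n1)C(=O)Nc1ccc(F)cc1F`: 4230 nM in this assay
Compound 3, `CCCCCCCN(CCCCCSc1nc(N)c2c[nH]nc2n1)C(=O)NC(C)C`: "not active" (no number reported) in this assay, no number given

Compound 1 and compound 2 sit within the usual scatter of each other. Compound 3 stands without a number; it is described only as not active, so its place on the scale is open. Compound 4, `CCCCCCCN(CCCCCSc1[nH]cnc2nncc1-2)C(=O)NC(C)C`, differs from compound 3 by a group of 9 heavy atoms (5 carbon, 4 nitrogen; one five-membered aromatic ring with 2 hetero atoms, one six-membered aromatic ring with 2 hetero atoms) in place of a group of 10 heavy atoms (5 carbon, 5 nitrogen; one five-membered aromatic ring with 2 hetero atoms, one six-membered aromatic ring with 2 hetero atoms), on a sulfur. Among the compounds with values here, no measured step of this kind exists, so neither the size nor the direction of the change can be read from the data. Because compound 3 is reported as "not active" (no number reported), compound 4 is expected to remain weak. Compound 4 is estimated at 30000 nM, with a range from 5000 nM to 150000 nM.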

Compound 4, half-maximal inhibitory concentration: 7130 nM
For compound 4 the middle estimate is 4.2-fold (0.62 log units) above the measured one, within the range that was stated.
By their numbers in this assay, from the lowest: compounds 1, 2 and 4 (each within the scatter of the next).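

Within the data shown here, compound 3 has no number, so no step from it to compound 4 can be read. Nothing measured here accounts for the result. Going by these compounds, the size and direction of the effect of exchanging the group on the sulfur remain open.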